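Phenoxy in place of chloro: an estimate for compound 4

The source may report more compounds than this note shows. Statements on the series, on what has been measured and on what is new or still open speak of the compounds shown alone.

Compound 1 `Nc1nc(NCc2cccc(F)c2)nc(-c2ccccc2CO)n1`: 4.52
Compound 2 `Nc1nc(NCc2ccc(Cl)cc2)nc(-c2ccccc2CO)n1`: 5.22
Compound 3 `COc1cccc(CNc2nc(N)nc(-c3ccccc3CO)n2)c1`: 4.11

In a functional assay on cells for positive allosteric modulation of G-protein coupled receptor 68 (Homo sapiens), read by a luciferase reporter and cAMP accumulation, with a stated time of 30 min, at pH 6.8 and pH 8.3, in the presence of a further agent that is not named here (on this read-out higher numbers stand for higher potency (the scale is a negative logarithm) and lower numbers for lower potency), compound 2 stands highest of the three numbers, as shown by a number 0.70 log units higher from compound 1 to compound 2 (beyond the scatter) and by a number 1.11 log units lower from compound 2 to compound 3 (beyond the scatter). Compound 4 `Nc1nc(NCc2ccc(Oc3ccccc3)cc2)nc(-c2ccccc2CO)n1` differs from compound 2 by phenoxy in place of chloro on an aromatic carbon. Among the compounds with values here, the two measured steps that bear on this change, a number 0.70 log units higher from compound 1 to compound 2 (beyond the scatter) and a number 1.11 log units lower from compound 2 to compound 3 (beyond the scatter), both concern the chloro group that now leaves, one modest and one large; no measured compound carries a phenoxy group, so its own effect is unknown. A modest step in this assay is therefore expected, with the direction uncertain. Compound 4 is estimated at 5.3, in the range 4.6 to 6. This estimate means an expected a number 0.08 log units higher from compound 2 to compound 4 (within the scatter).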

Compound 4, negative logarithm of the antagonist equilibrium constant: 5.19
The estimate for compound 4 lay 0.11 log units above the measured number, and the stated range covers the measured number.
By their numbers in this assay, from the lowest: compound 3; then compound 1; then compounds 4 and 2 (each within the scatter of the next).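

In this assay, the step of a number 0.03 log units lower from compound 2 to compound 4 (within the scatter) shows that this aromatic carbon, para to a large group, can carry phenoxy, with its six-membered aromatic ring and hydrogen-bond acceptor, in place of chloro without a change beyond the scatter. Within the data shown here, the earlier compounds showed only small groups on the benzyl ring, so this is the first sign that a group of this size keeps the number level with that of compound 2. No evidence here bears on why the two groups give matching numbers. Going by these compounds, what remains open is whether an amine, a carboxylic acid or a longer chain on this same carbon would also keep the number level.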